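Enone ring in place of dimethylcarbamoyl on the ring nitrogen

This account rests on a few compounds, and the source may have more. Where it says the series, first, only, none or still open, it means among the compounds named here.

Compound 3 `C[C@@H](O[C@@H]1CN(C(=O)N(C)C)C[C@H]1c1ccc(F)cc1)c1cc(C(F)(F)F)cc(C(F)(F)F)c1` gives the highest number of the three in an assay on CHO cells for displacement of a labelled ligand from Substance-P receptor (Homo sapiens) (a lower number here means a stronger inhibitor, a higher number a weaker inhibitor), 0.38 nM, but its gap to compound 2 `C[C@@H](O[C@@H]1CN(C(=O)[C@@H]2COC(=O)N2)C[C@H]1c1ccc(F)cc1)c1cc(C(F)(F)F)cc(C(F)(F)F)c1` at 0.34 nM lies within the scatter; only compound 1 `Cc1cnc(C(=O)N2C[C@@H](O[C@H](C)c3cc(C(F)(F)F)cc(C(F)(F)F)c3)[C@H](c3ccc(F)cc3)C2)cn1`, at 0.12 nM, stands apart. The change to compound 4 `CC1=C(N2C[C@@H](O[C@H](C)c3cc(C(F)(F)F)cc(C(F)(F)F)c3)[C@H](c3ccc(F)cc3)C2)CCC1=O` is 2-methyl-3-oxocyclopent-1-en-1-yl in place of dimethylcarbamoyl on an amine nitrogen in a ring. Every measured step alters this same substituent on the shared core: a 2.8-fold higher number from compound 1 to compound 2 (0.45 log units; beyond the scatter), a 3.2-fold higher number from compound 1 to compound 3 (0.50 log units; beyond the scatter) and a 1.1-fold higher number from compound 2 to compound 3 (0.05 log units; within the scatter), none larger than modest despite quite different groups. A modest change at most is therefore expected in this assay, with no clear direction. Compound 4 is estimated at 0.5 nM, within 0.15 nM to 2 nM. That estimate amounts to an expected step of a 1.3-fold higher number from compound 3 to compound 4 (0.12 log units; within the scatter).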

Compound 4, half-maximal inhibitory concentration: 0.13 nM
Estimate against measurement, compound 4: 3.8-fold (0.59 log units) above; measured number below the stated range.
By their numbers in this assay, from the lowest: compounds 1 and 4 (each within the scatter of the next); then compounds 2 and 3 (each within the scatter of the next).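

In this assay, the 2-methyl-3-oxocyclopent-1-en-1-yl group shows that a carbonyl directly on the amine nitrogen in a ring is not needed among these compounds: the steps are a 2.9-fold lower number from compound 3 to compound 4 (0.47 log units; beyond the scatter) and a 2.6-fold lower number from compound 2 to compound 4 (0.42 log units; beyond the scatter). Compound 4 also matches the best acyl example, with a 1.1-fold higher number from compound 1 to compound 4 (0.03 log units; within the scatter). No supporting data explain these steps.

Going by these compounds, whether the methyl or the ketone of the new ring carries the result stays open. So does how a plain cyclopentyl group or an open-chain enone would read at this nitrogen.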